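Swapping a Chain for a Ring on Sulfur

The source may hold more compounds than are shown below. What is called first, only, known or untested is meant among the compounds shown, and "the series" means these compounds.

Measured in a functional assay on HT cells (Homo sapiens) for antiproliferative activity, read by fluorescence, with a stated time of 72 h; a higher number here means a weaker inhibitor of growth, a lower number a stronger inhibitor of growth:
Compound 1 `CC(C)c1n[nH]c2c(NCc3ccc(-c4ccccn4)cc3)nc(SCC(O)CO)nc12`: 21 nM
Compound 2 `CC(C)c1n[nH]c2c(NCc3ccc(-c4ccccn4)cc3)nc(SCC(O)CN)nc12`: 55 nM
Compound 3 `CNCCSc1nc(NCc2ccc(-c3ccccn3)cc2)c2[nH]nc(C(C)C)c2n1`: 56 nM

Compound 3 shares the high end of these numbers. Its gap to the nearest value is a 1.0-fold higher number from compound 2 to compound 3 (0.01 log units; within the scatter), and its gap to the lowest value is a 2.7-fold higher number from compound 1 to compound 3 (0.43 log units; beyond the scatter).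

Compound 4 `CC(C)c1n[nH]c2c(NCc3ccc(-c4ccccn4)cc3)nc(SC3CCCCC3N)nc12` keeps the shared core and changes one group: 2-aminocyclohexyl in place of 2-(methylamino)ethyl on a sulfur. In words, 2-aminocyclohexyl stands in place of 2-(methylamino)ethyl on a sulfur.

The measured steps that bear on this are the other chain changes on that sulfur. These were small: a 2.6-fold higher number from compound 1 to compound 2 (0.42 log units; beyond the scatter) is modest, and a 1.0-fold higher number from compound 2 to compound 3 (0.01 log units; within the scatter) is no real change. Going by the values given here, none of the measured compounds carries a ring there, so the ring itself remains untested and the uncertainty is wide. No step beyond the scatter is therefore expected in this assay. The expected step is a 1.1-fold lower number from compound 3 to compound 4 (0.05 log units; within the scatter). For compound 4 the estimate is 50 nM, with an expected range of 20 nM to 130 nM.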

Compound 4, concentration for 50% growth inhibition: 139 nM
For compound 4 the middle estimate is 2.8-fold (0.44 log units) below the measured one, and the stated range ends below it.
By their numbers in this assay, from the lowest: compound 1; then compounds 2 and 3 (each within the scatter of the next); then compound 4.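

In this assay, going by these compounds alone, the swap to a ring gives a 2.5-fold higher number from compound 3 to compound 4 (0.39 log units; beyond the scatter) and is the first change on this sulfur to bring in a ring. Set against the other chains, the same ring gives a 2.5-fold higher number from compound 2 to compound 4 (0.40 log units; beyond the scatter) with 3-amino-2-hydroxypropyl as the starting group and a 6.6-fold higher number from compound 1 to compound 4 (0.82 log units; beyond the scatter) with 2,3-dihydroxypropyl as the starting group. Compound 4 therefore has the highest number of the four, so a six-membered carbon ring on this sulfur keeps growth inhibition but weakens it compared with all three open chains.

Going by these compounds, whether this follows from the ring or from the amine on it stays open: a cyclohexyl ring carrying a hydroxy group instead of the amino group, or a cyclopentyl ring carrying the amino group, would help separate the two. Nothing shown gives a measured reason for the weaker number.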